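Swapping a methoxyphenyl for a chlorophenyl

The compounds below may be only part of what the source reports. "The series", "measured", "known", "first", "only" and "open" are said of these compounds alone.

In a functional assay on NCI-H727 cells (Homo sapiens) for cytotoxicity, with a stated time of 48 h (on this read-out higher numbers stand for weaker inhibition and lower numbers for stronger inhibition), compound 1 (`COc1cc(OC)c(C(=O)/C=C/c2ccccc2SC)c(OC)c1`) gives 8700 nM and compound 2 (`COc1cccc(/C=C/C(=O)c2c(OC)cc(OC)cc2OC)c1`) gives 8200 nM. Within the data shown here, compound 2 therefore stands level with compound 1, the only other number available. Compound 3 (`COc1cc(OC)c(C(=O)/C=C/c2ccc(Cl)cc2)c(OC)c1`) has not been measured, and it differs from compound 2 in one group: 4-chlorophenyl in place of 3-methoxyphenyl on a double-bonded chain carbon bound to a double-bonded chain carbon. Among the measured compounds shown here, the sole measured step exchanged that same group, and it was small: a 1.1-fold lower number from compound 1 to compound 2 (0.03 log units; within the scatter). One step is thin evidence, but on that basis no change beyond the scatter is expected in this assay, and the expected step is a 1.1-fold lower number from compound 2 to compound 3 (0.04 log units; within the scatter). The estimate for compound 3 is 7500 nM, with an expected range of 3000 nM to 17000 nM.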

Compound 3, half-maximal inhibitory concentration: 6000 nM
Beside the measured number, compound 3's estimate is 1.3-fold (0.10 log units) above it; the measured number falls inside the stated range.
By their numbers in this assay, from the lowest: compounds 3, 2 and 1 (each within the scatter of the next).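

A third group on a double-bonded chain carbon bound to a double-bonded chain carbon still stays within the scatter in this assay, with a 1.4-fold lower number from compound 2 to compound 3 (0.14 log units; within the scatter) and a 1.5-fold lower number from compound 1 to compound 3 (0.16 log units; within the scatter). So 4-chlorophenyl, which brings chlorine and has 0 hydrogen-bond acceptors, reads level with both 3-methoxyphenyl and 2-(methylsulfanyl)phenyl. Nothing available explains why these three groups read alike.

Whether this place tolerates any group equally stays open, since all three groups shown are substituted phenyl rings. An amine, a carboxylic acid or a longer chain here might read quite differently.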